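The source may hold more compounds than are shown below. What is called first, only, known or untested is meant among the compounds shown, and "the series" means these compounds.

Three measured compounds set the frame. In a functional assay on CHO cells for agonist activity at Free fatty acid receptor 1 (Homo sapiens), read by FLIPR and calcium flux, in the presence of a further agent that is not named here (on this read-out higher numbers stand for an effect only at larger amounts of compound and lower numbers for an effect already at smaller amounts), compound 1, `Cc1cccc(-c2noc(COc3ccc(CCC(=O)O)cc3Cl)n2)c1`, gives 4580 nM, and compound 3, `CC(Oc1ccc(CCC(=O)O)cc1)c1nc(-c2cccs2)no1`, gives 4000 nM. Compound 2, `O=C(O)CCc1ccc(OCc2coc(-c3cccc(F)c3)n2)cc1`, gives 560 nM in this assay, the lowest of the three numbers, with both other compounds standing beyond the scatter above it. The unmeasured compound 4, `O=C(O)CCc1ccc(OCc2coc(-c3cccc(Cl)c3)n2)cc1`, differs from compound 2 only by chloro in place of fluoro on an aromatic carbon, on the group read as 3-fluorophenyl to 3-chlorophenyl. For the measured compounds named here, no measured pair shows this exchange here, so the direction can only be guessed; a step of at most the usual scatter is expected, leaning slightly toward a lower number. Compound 4 is therefore estimated at 450 nM (range 180 nM to 1100 nM), the expected step being a 1.2-fold lower number from compound 2 to compound 4 (0.09 log units; within the scatter).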

Compound 4, half-maximal effective concentration: 160 nM
For compound 4 the middle estimate is 2.8-fold (0.45 log units) above the measured one; the whole stated range lies above it.
By their numbers in this assay, from the lowest: compound 4; then compound 2; then compounds 3 and 1 (each within the scatter of the next).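

In this assay, for the compounds shown here, the exchange of 3-fluorophenyl to 3-chlorophenyl gives a 3.5-fold lower number from compound 2 to compound 4 (0.54 log units; beyond the scatter) and is the first comparison here of compounds differing in one place. It shows that a single-atom exchange at this aromatic carbon, meta to a large group, can move the number beyond the scatter. Nothing measured here gives a cause for this step. As far as these compounds go, whether bromo, methyl or trifluoromethyl at this position would continue the trend remains open. So does whether the same exchange would have a similar effect on the cores of compound 1 or compound 3.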